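A few compounds are considered here, and "the series" means these few. Any claim that something is new, unique, unknown or untested is made for them only; others in the source may bear on it.

Going by the values given here, in a functional assay on HL-60 cells (Homo sapiens) for activation, read by flow cytometry, with a stated time of 4 days (on this read-out higher numbers stand for an effect only at larger amounts of compound and lower numbers for an effect already at smaller amounts), compound 2 `COc1ccc(-n2cnc3cnc(-c4ccc(F)cc4C)cc32)cc1` gives 6 nM, the lowest number of the three compounds measured so far. Compound 1 `COc1ccc(-n2cnc3cnc(-c4ccc(F)cc4C)cc32)cc1OC` gives 15 nM, and compound 3 `CCOc1ccc(-n2cnc3cnc(-c4ccc(F)cc4C)cc32)cc1` gives 19 nM. Compound 4 `COc1ncc(-n2cnc3cnc(-c4ccc(F)cc4C)cc32)cn1` keeps the shared core but carries 2-methoxypyrimidin-5-yl in place of 4-methoxyphenyl on an aromatic nitrogen.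

Among the compounds with values here, two measured steps bear on this change. Putting hydrogen in place of a methoxy gave a 2.5-fold lower number from compound 1 to compound 2 (0.40 log units; beyond the scatter), and adding a methyl to the methoxy chain gave a 3.2-fold higher number from compound 2 to compound 3 (0.50 log units; beyond the scatter). Both steps were modest, though beyond the usual scatter. Within the data shown here, neither alters the atoms of the aromatic ring itself, so they offer only a rough guide, and no measured compound yet has nitrogen in that ring. Compound 2 gives 6 nM, and compound 1 and compound 3 both stand above it, so a modest step to a higher number is expected in this assay. The expected step is a 3.3-fold higher number from compound 2 to compound 4 (0.52 log units; beyond the scatter). For compound 4 the estimated value is 20 nM, with an expected range from 6 nM to 70 nM.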

Compound 4, half-maximal effective concentration: 2900 nM
Beside the measured number, compound 4's estimate is 150-fold (2.16 log units) below it; measured number outside the range, above it.
By their numbers in this assay, from the lowest: compound 2; then compounds 1 and 3 (each within the scatter of the next); then compound 4.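

In this assay, the swap at this aromatic nitrogen gives a 480-fold higher number from compound 2 to compound 4 (2.68 log units; beyond the scatter) and is far larger than the modest steps seen when only the groups on the ring changed, a 2.5-fold lower number from compound 1 to compound 2 (0.40 log units; beyond the scatter) and a 3.2-fold higher number from compound 2 to compound 3 (0.50 log units; beyond the scatter). So this position tolerates changes to the ring's substituents much better than nitrogen atoms in the ring itself, at least across these compounds. Both groups have the same heavy-atom count and no net charge, differing in ring atoms and hydrogen-bond acceptors, but no measurement here explains the jump.

On these data alone, it remains open whether a methoxypyridinyl group, with one ring nitrogen, would give a step as large as the one seen with 2-methoxypyrimidin-5-yl. Also open, as far as these compounds go, is how an amine in place of the methoxy on 2-methoxypyrimidin-5-yl would read.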